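A few compounds are considered here, and "the series" means these few. Any claim that something is new, unique, unknown or untested is made for them only; others in the source may bear on it.

In a functional assay on NCI-H1975 cells (Homo sapiens) for antiproliferative activity, with a stated time of 72 h (on this read-out lower numbers stand for stronger inhibition of growth and higher numbers for weaker inhibition of growth), compound 3 `CN(Cc1ccccc1)C(=O)c1cc(Cl)c(O)cc1O` gives 35500 nM. That is level, within the scatter, with compound 2 `Cc1ccc(CN(C)C(=O)c2cc(Cl)c(O)cc2O)cc1` at 34300 nM, while compound 1 `O=C(NCc1ccccc1)c1cc(Cl)c(O)cc1O` gives the highest number, 86200 nM. Compound 4 `CCCNC(=O)c1ccc(CN(C)C(=O)c2cc(Cl)c(O)cc2O)cc1` has propylcarbamoyl in place of hydrogen on an aromatic carbon, para to a large group: propylcarbamoyl in place of hydrogen on an aromatic carbon. Hydrogen in place of methyl on that same carbon gave a 1.0-fold higher number from compound 2 to compound 3 (0.01 log units; within the scatter), which is the closest precedent. Methyl in place of hydrogen on the amide-type nitrogen gave a 2.4-fold lower number from compound 1 to compound 3 (0.39 log units; beyond the scatter), but that nitrogen stays unchanged here. Neither step covers a group this large, so the expectation is uncertain. The expected step is a modest one toward a lower number, a 1.8-fold lower number from compound 3 to compound 4 (0.25 log units; within the scatter). For compound 4 the estimate is 20000 nM, with an expected range of 5000 nM to 60000 nM.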

Compound 4, concentration for 50% growth inhibition: 20800 nM
The estimate for compound 4 lay 1.0-fold (0.02 log units) below the measured number, within the range that was stated.
By their numbers in this assay, from the lowest: compounds 4, 2 and 3 (each within the scatter of the next); then compound 1.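

In this assay, a group as large as propylcarbamoyl, on the aromatic carbon para to a large group, leaves the number level with both smaller substituents: hydrogen (a 1.7-fold lower number from compound 3 to compound 4 (0.23 log units; within the scatter)) and methyl (a 1.6-fold lower number from compound 2 to compound 4 (0.22 log units; within the scatter)). Both steps lie within the scatter, so this place accepts the larger group without a real gain or loss in growth inhibition. No measurement shown here accounts for this. On these data alone, whether an amine, a carboxylic acid or a longer chain at this carbon would move the number beyond the scatter stays open.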